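The compounds below may be only part of what the source reports. "The series", "measured", "known", "first", "only" and "open" are said of these compounds alone.

Within the data shown here, compound 1 `Cc1cn(Cc2ccc(Cl)cc2Cl)c2c(-c3nnc(NS(=O)(=O)c4cc(Cl)c(Cl)s4)o3)cc(F)cc12` gives 46.4% in an ADME assay on microsomes from liver (Rattus norvegicus) for metabolic stability, with a stated time of 30 min (a lower number here means that less of the compound is left, a higher number that more of the compound is left), the higher of the two numbers so far in this assay. Compound 2 `Cc1cn(Cc2ccc3ccccc3c2)c2c(-c3cc(NS(=O)(=O)c4ccc(F)c(F)c4)no3)cc(F)cc12` gives 9.9% in this assay; the two structures differ in more than one place, so only the two values themselves can be set side by side. Compound 3 `Cc1cn(Cc2ccc(Cl)cc2Cl)c2c(-c3nnc(NS(=O)(=O)c4ccc(F)c(F)c4)o3)cc(F)cc12` carries 3,4-difluorophenyl in place of 4,5-dichlorothiophen-2-yl on a sulfonyl sulfur. Among the measured compounds shown here, no measured pair isolates this change; compound 2, which also bears the (3,4-difluorophenyl)sulfonyl group, gives 9.9% but is not a one-step comparison. For compound 3 a moderate drop is expected, as the step of a number 13.4 percentage points lower from compound 1 to compound 3 (beyond the scatter) shows. The estimate for compound 3 is 33%, expected to fall between 14% and 58%.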

Compound 3, percent of the compound remaining: 42.5%
Estimate against measurement, compound 3: 9.5 percentage points below; measured number inside the range.
By their numbers in this assay, from the lowest: compound 2; then compounds 3 and 1 (each within the scatter of the next).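

In this assay, among these compounds, 3,4-difluorophenyl in place of 4,5-dichlorothiophen-2-yl on a sulfonyl sulfur gives a number 3.9 percentage points lower from compound 1 to compound 3 (within the scatter) and provides the first one-place reading at this position. With the rest of compound 1 unchanged, an aromatic ring of carbon only can therefore replace the dichlorinated thiophene without a change beyond the scatter. No measurement at hand explains this result.

Still open, going by these compounds, is whether a much smaller or non-aromatic group on the sulfonyl sulfur, such as methyl or a piperidine, would hold the number in this range. The contribution of the other places in compound 1 also remains unresolved.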